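This account rests on a few compounds, and the source may have more. Where it says the series, first, only, none or still open, it means among the compounds named here.

In a functional assay (aorta) with Rattus norvegicus as the target (on this read-out higher numbers stand for weaker inhibition and lower numbers for stronger inhibition), compound 1 `CC1(C)Oc2ccc(C#N)cc2[C@H](N(CC#N)c2ccccc2)[C@H]1O` gives 59000 nM. Within the data shown here, compound 2 `CCOC(=O)NN(c1ccccc1)[C@H]1c2cc(C#N)ccc2OC(C)(C)[C@@H]1O` gives 2200 nM in this assay, and the single change between them brought a 27-fold lower number from compound 1 to compound 2 (1.43 log units; beyond the scatter), so compound 2 stands at the lowest of the two numbers, with compound 1 the only neighbour.

Compound 3 `Cc1noc(CN(c2ccccc2)[C@H]2c3cc(C#N)ccc3OC(C)(C)[C@@H]2O)n1` differs from compound 2 in one place: (3-methyl-1,2,4-oxadiazol-5-yl)methyl in place of (ethoxycarbonyl)amino on a nitrogen on an aromatic ring. Among the measured compounds shown here, the only measured step that bears on this change is the one from compound 1 to compound 2, in which a cyanomethyl on that nitrogen gave a far higher number than the (ethoxycarbonyl)amino. The group that enters compound 3 is, like cyanomethyl, a carbon-linked group without a hydrogen-bond donor, so the number is expected to move back toward that of compound 1 by a 4.5-fold higher number from compound 2 to compound 3 (0.66 log units; beyond the scatter). Compound 3 is therefore estimated at 10000 nM, within a range from 2500 nM to 40000 nM.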

Compound 3, half-maximal inhibitory concentration: > 30000 nM
Compound 3: only a limit was reported; the forecaster's own chance of this, stated with the estimate: 10%; middle value at least 3.0-fold (0.47 log units) away from the limit.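

For compound 3, this assay gives a limit and not a number: the limit of > 30000 nM in this assay, at which 1 of the 3 values shown sits. Even so, the limit is enough to show that this position is sensitive to the group placed there, as replacing (ethoxycarbonyl)amino with (3-methyl-1,2,4-oxadiazol-5-yl)methyl gives an at least 13-fold higher number from compound 2 to compound 3 (1.13 log units; beyond the scatter). Thus a second group on this nitrogen, this one carrying a five-membered aromatic ring, fails to keep the low number of compound 2, which so far stands alone among the three compounds.

On these data alone, the step from compound 1 to compound 3 cannot be read, so it remains unknown how 3-methyl-1,2,4-oxadiazol-5-yl compares with cyano on that chain carbon. As far as these compounds go, it is also open whether a plain amino group or an acetylamino group on this nitrogen would retain the low number of compound 2, or whether the complete (ethoxycarbonyl)amino group is needed.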